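A few compounds are considered here, and "the series" means these few. Any claim that something is new, unique, unknown or untested is made for them only; others in the source may bear on it.

Working notes on the series. The shared core is common to all four analogues and differs only in the aryl group that sits on it. Compound 1 `CCC1=C(O)c2c(oc(-c3ccc(OC)cc3)cc2=O)C(CC)(CC)C1=O` carries a 4-methoxyphenyl group and gives 17.7 uM in a functional assay on KB cells (Homo sapiens) for antiproliferative activity, read by sulforhodamine B assay, with a stated time of 3 days; a lower number here means that less compound is needed, a higher number that more compound is needed for the effect. Compound 2 `CCC1=C(O)c2c(oc(-c3ccc(CBr)cc3)cc2=O)C(CC)(CC)C1=O` carries a 4-(bromomethyl)phenyl group; in this assay compound 2 returns only a limit, > 46.5 uM, and so has no number of its own (the limit of > 46.5 uM in this assay, at which 1 of the 3 values shown sits). Compound 3 `CCC1=C(O)c2c(oc(-c3cccc(OC)c3)cc2=O)C(CC)(CC)C1=O` carries a 3-methoxyphenyl group and gives 13.3 uM in this assay, the lowest of the two numbers available, with compound 1 nearest; the two sit within the scatter of each other, as the step of a 1.3-fold lower number from compound 1 to compound 3 (0.12 log units; within the scatter) shows. The step of an at least 2.6-fold higher number from compound 1 to compound 2 (0.41 log units; beyond the scatter) and the step of an at least 3.4-fold lower number from compound 2 to compound 3 (0.54 log units; beyond the scatter) both say that the bromomethyl analogue falls beyond the scatter of the methoxy analogues.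

Compound 4 `CCC1=C(O)c2c(oc(-c3cc(C)c(C)cc3C)cc2=O)C(CC)(CC)C1=O` is not yet measured. Its change from compound 3 is 2,4,5-trimethylphenyl in place of 3-methoxyphenyl on an aromatic carbon. Within the data shown here, no measured step exchanges methoxy for methyl, nor adds substituents to the phenyl ring; the only steps available show that moving methoxy on the ring barely matters, while bromomethyl costs at least modestly. On that basis the step of a 1.5-fold higher number from compound 3 to compound 4 (0.18 log units; within the scatter) is expected to be small, likely within the scatter or a mild rise in the number. Compound 4 is therefore estimated at 20 uM in this assay, within 8 uM to 50 uM.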

Compound 4, concentration for half-maximal effect: 8.2 uM
For compound 4 the middle estimate is 2.4-fold (0.39 log units) above the measured one; the range from low to high includes it.
By their numbers in this assay, from the lowest: compounds 4, 3 and 1 (each within the scatter of the next, the first and the last beyond it). At a limit, above all of these: compound 2.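

At this position on the shared core, next to the ring oxygen, an aryl group carrying only methyl groups reads in the same range as one carrying methoxy, so in this assay an oxygen on the phenyl ring is not required for a measurable number: the step is a 1.6-fold lower number from compound 3 to compound 4 (0.21 log units; within the scatter). Against the 4-methoxyphenyl analogue, the same kind of exchange gives the first step among measurable numbers that lies beyond the scatter, a 2.2-fold lower number from compound 1 to compound 4 (0.33 log units; beyond the scatter), whereas moving methoxy around the ring did not open such a gap. The widest step, an at least 5.6-fold lower number from compound 2 to compound 4 (0.75 log units; beyond the scatter), rests on a limit for the bromomethyl analogue rather than on a number, so its full size stays unknown: the limit of > 46.5 uM in this assay, at which 1 of the 4 values shown sits.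

The compounds shown leave open whether a single methyl group, at any one of these ring places, would match the 2,4,5-trimethylphenyl group. Also open, going by these compounds, is how an amine or a carboxylic acid on the phenyl ring would read in this assay, and whether a longer chain in place of the ethyl groups on the shared core would be tolerated.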